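The compounds below may be only part of what the source reports. "The series", "measured", "known", "first", "only" and "open" are said of these compounds alone.

Measured so far:
compound 1 `CCC[C@H](CCn1cncn1)c1ccccc1` — 58.4 ug/mL
compound 2 `CCCC[C@H](CCn1cncn1)c1ccccc1` — 50.2 ug/mL

Both share the core shown beside them. In an ADME assay on HEp-2 cells (Homo sapiens) for cytotoxicity, read by MTT assay, with a stated time of 3 days (on this read-out higher numbers stand for lower toxicity in this test and lower numbers for higher toxicity in this test), compound 1 gives 58.4 ug/mL and compound 2 gives 50.2 ug/mL. Within the data shown here, the single step in hand, a 1.2-fold lower number from compound 1 to compound 2 (0.07 log units; within the scatter), lies within the scatter. Compound 2 holds the lower of the two numbers, but the gap to compound 1 is within the scatter, so no order between them is claimed.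

The next compound, compound 3 `c1ccc(C[C@H](CCn2cncn2)c2ccccc2)cc1`, differs from compound 2 by phenyl in place of propyl on a saturated chain carbon, two bonds along the chain from an aromatic carbon. Among the measured compounds shown here, no measured step bears directly on this exchange: the one step available concerns a methyl in place of hydrogen and did not move the number, and it says nothing about a phenyl in place of propyl. With nothing pointing the other way, compound 3 is expected to land close to the number above, with a modest lean toward a lower number: a 1.3-fold lower number from compound 2 to compound 3 (0.12 log units; within the scatter). For compound 3 the estimate is 38 ug/mL, in the range 18 ug/mL to 80 ug/mL.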

Compound 3, half-maximal cytotoxic concentration: 60.9 ug/mL
Compound 3: middle estimate off by 1.6-fold (0.20 log units), on the low side, within the range that was stated.
By their numbers in this assay, from the lowest: compounds 2, 1 and 3 (each within the scatter of the next).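

In this assay, phenyl in place of propyl on a saturated chain carbon, two bonds along the chain from an aromatic carbon, gives a 1.2-fold higher number from compound 2 to compound 3 (0.08 log units; within the scatter) and so stays level with the chain. Phenyl in place of ethyl at the same place gives a 1.0-fold higher number from compound 1 to compound 3 (0.02 log units; within the scatter) and likewise shows no separation. This place therefore carries a six-membered aromatic ring of carbon only as well as an open chain, with all three compounds within the scatter of each other, and no measurement to hand accounts for this.

Open, as far as these compounds go, is whether an amine or a carboxylic acid on the added phenyl would move the number beyond the scatter in this assay. A chain longer than those shown also remains open at this place.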